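Lipophilicity notes: aryl swap on the saturated ring carbon

The compounds below may be only part of what the source reports. "The series", "measured", "known", "first", "only" and "open" are said of these compounds alone.

Measured so far in a physicochemical assay for lipophilicity, in phosphate buffer, measured as octanol-water partition, with a stated time of 24 h; on this read-out lower numbers stand for lower lipophilicity and higher numbers for higher lipophilicity:
compound 1 `O=C(CN1C(=O)c2ccccc2C1=O)NN1C(=O)CSC1c1c(F)cccc1Cl` gives 3.79
compound 2 `Cc1ccc(C2SCC(=O)N2NC(=O)CN2C(=O)c3ccccc3C2=O)cc1` gives 2.97
compound 3 `CN(C)c1ccc(C2SCC(=O)N2NC(=O)CN2C(=O)c3ccccc3C2=O)cc1` gives 2.84

Compound 2 sits second highest of the three numbers in this assay. Its nearest neighbour is compound 3, where the step of a number 0.13 log units lower from compound 2 to compound 3 (within the scatter) is within the scatter, so the two are not told apart. The furthest is compound 1, and the step of a number 0.82 log units lower from compound 1 to compound 2 (beyond the scatter) is beyond the scatter. The other swap at the same saturated ring carbon, a number 0.95 log units lower from compound 1 to compound 3 (beyond the scatter), is of similar size.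

Compound 4 `O=C(CN1C(=O)c2ccccc2C1=O)NN1C(=O)CSC1c1cccnc1` is not yet measured. Its change from compound 2 is pyridin-3-yl in place of 4-methylphenyl on a saturated ring carbon. The two measured aryl swaps at this position, from compound 1 to compound 2 and from compound 1 to compound 3, each moved this assay by a modest amount, so a swap at this carbon is seen to shift the number beyond the scatter; none of them placed a ring hetero atom there, so the size of the present step is not directly shown. The step is expected to be downward, a number 1.17 log units lower from compound 2 to compound 4 (beyond the scatter). Compound 4 is therefore estimated at 1.8, with a range from 1.3 to 2.4.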

Compound 4, partition coefficient: 1.25
Compound 4: middle estimate off by 0.55 log units, on the high side; measured number below the stated range.
By their numbers in this assay, from the lowest: compound 4; then compounds 3 and 2 (each within the scatter of the next); then compound 1.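

At this saturated ring carbon, a six-membered aromatic ring with a hetero atom goes with a far bigger drop in this assay than the swaps among carbon-only aryl rings: a number 1.72 log units lower from compound 2 to compound 4 (beyond the scatter) and a number 1.59 log units lower from compound 3 to compound 4 (beyond the scatter) are both large. The full span at this one position now reaches a number 2.54 log units lower from compound 1 to compound 4 (beyond the scatter) and the choice of ring here outweighs the change from methyl to dimethylamino, which compound 2 and compound 3 leave within the scatter. No measurement on hand accounts for the size of this drop.

Pyridin-3-yl is the only ring with a hetero atom shown, so it remains open whether a thiophene or pyrimidine ring on this carbon would give a similar number. Also open, as far as these compounds go, is how an unsubstituted phenyl would sit relative to compound 4.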